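A few compounds are considered here, and "the series" means these few. Any claim that something is new, unique, unknown or untested is made for them only; others in the source may bear on it.

Measured so far in a functional assay on HCT-116 cells (Homo sapiens) for antiproliferative activity, read by sulforhodamine B assay, with a stated time of 48 h; on this read-out lower numbers stand for stronger inhibition and higher numbers for weaker inhibition:
- compound 1 `C/C=C(\C)C(=O)O[C@H]1C=CC(=O)O[C@H]1CCC(=O)[C@H](C)O`: 18000 nM
- compound 2 `C/C=C(\C)C(=O)O[C@H]1C=CC(=O)O[C@H]1COC(=O)[C@H](C)O`: 11000 nM

Only these two compounds have numbers, and they cannot be told apart, since their values lie within the scatter of each other. Compound 2 therefore has no clear rank and serves here simply as the starting point, with its 11000 nM.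

The next compound is compound 3 `C/C=C(\C)C(=O)O[C@H]1C=CC(=O)O[C@H]1CNC(=O)[C@H](C)O`, which carries ((1-hydroxyethyl)carbonyl)amino in place of ((1-hydroxyethyl)carbonyl)oxy on a saturated chain carbon bound to a saturated ring carbon.

Among the compounds with values here, one measured step bears on this change, as it was made at the same place: ((1-hydroxyethyl)carbonyl)oxy in place of ((1-hydroxyethyl)carbonyl)methyl gave a 1.6-fold lower number from compound 1 to compound 2 (0.21 log units; within the scatter). Within the data shown here, a single step is thin evidence, and no measured compound yet carries the new group. Among the measured compounds shown here, still, the only swap seen at this place did not move the number beyond the scatter, so no real shift is expected in this assay.

The expected change is small, within the scatter, at a 1.3-fold higher number from compound 2 to compound 3 (0.10 log units; within the scatter).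

Compound 3 is estimated at 14000 nM, with an expected range from 6000 nM to 35000 nM.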

Compound 3, half-maximal inhibitory concentration: 25000 nM
For compound 3 the middle estimate is 1.8-fold (0.25 log units) below the measured one; measured number inside the range.
By their numbers in this assay, from the lowest: compounds 2, 1 and 3 (each within the scatter of the next, the first and the last beyond it).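

In this assay the linking atom at this place now shows its first change beyond the scatter: ((1-hydroxyethyl)carbonyl)amino in place of ((1-hydroxyethyl)carbonyl)oxy gave a 2.3-fold higher number from compound 2 to compound 3 (0.36 log units; beyond the scatter), a modest loss of inhibition on a single pair. The same amino group in place of ((1-hydroxyethyl)carbonyl)methyl gave a 1.4-fold higher number from compound 1 to compound 3 (0.14 log units; within the scatter), so compound 1 cannot be told apart from either neighbour, and only compound 2 and compound 3 separate, which means this position responds to the swap, but only slightly and only between these two ends of the series. No measurement is at hand that would explain the shift.

The compounds shown leave open how a plain amine or a carboxylic acid on this saturated chain carbon would read, since all three keep the (1-hydroxyethyl)carbonyl part and vary only the atom that links it. They also leave open whether a longer chain in place of that part, or a methyl group on the amide nitrogen, would move the number further in either direction.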